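The source may report more compounds than this note shows. Statements on the series, on what has been measured and on what is new or still open speak of the compounds shown alone.

Compounds measured so far:

Compound 1, `CCCCCCCC[C@@]1(C)SC(=O)C=C1OC`. In a functional assay on MCF7 cells (Homo sapiens) for inhibition (on this read-out lower numbers stand for stronger inhibition and higher numbers for weaker inhibition), compound 1 gives > 50 ug/mL, which is a limit of the assay rather than a number.

Compound 2, `C=CCOC1=CC(=O)S[C@]1(C)CCCCCCCC`. In this assay compound 2 gives > 50 ug/mL, again a limit and not a number.

Compound 3, `C=CCC1(C)C(=O)S[C@](C)(CCCCCCCC)C1=O`. In this assay compound 3 gives > 50 ug/mL, once more a limit.

All three measured compounds therefore sit at the same place: the limit of > 50 ug/mL in this assay, at which 3 of the 3 values shown sit. The structural change from compound 1 to compound 2 is vinyl in place of hydrogen on a saturated chain carbon bound to an oxygen on an unsaturated carbon. Its effect in this assay is a step that the two limits leave unreadable from compound 1 to compound 2, so that step tells nothing about direction or size.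

Compound 4, `C=CCC1(CC=C)C(=O)S[C@](C)(CCCCCCCC)C1=O`, has not yet been measured in this assay. It differs from compound 3 by vinyl in place of hydrogen on a saturated chain carbon bound to a saturated ring carbon. For the measured compounds named here, this is the same kind of change as the one from compound 1 to compound 2, but not the same: there the place was a saturated chain carbon bound to an oxygen on an unsaturated carbon, here it is a saturated chain carbon bound to a saturated ring carbon. The difference between the core of compound 1 and the core of compound 3 is not broken down here.

Going by the values given here, with every measured value a limit, the only guide is that compound 3 itself gives > 50 ug/mL, and the earlier step of the same kind was unreadable. The step from compound 3 to compound 4 is expected to be a step that the limit leaves unreadable from compound 3 to compound 4. Compound 4 is expected to give about 70 ug/mL in this assay, with a wide range from 20 ug/mL to 250 ug/mL, and most likely the assay will again report only a limit.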

Compound 4, half-maximal inhibitory concentration: > 50 ug/mL
Compound 4: only a limit was reported (the forecaster's own chance of this, stated with the estimate: 80%); the middle value is on the limit's open side.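

In this assay compound 4 gives > 50 ug/mL, which is a limit of the assay and not a number. For the compounds shown here, no step from compound 3 to compound 4 can be read, because both compounds sit at the same limit: the limit of > 50 ug/mL in this assay, at which 4 of the 4 values shown sit. The compounds shown leave open how strongly any of them inhibits in this assay, and whether vinyl in place of hydrogen changes that at all.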